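The compounds below may be only part of what the source reports. "The series", "measured", "known", "first", "only" and "open" are said of these compounds alone.

The study began with two compounds tested in a functional assay on the whole organism (strain Wistar) with Rattus norvegicus as the target; a higher number here means that more compound is needed for the effect, a lower number that less compound is needed. Compound 1 `O=S(=O)(c1cc(F)cc(F)c1)c1cnc2cc(F)ccc2c1-c1cccc(F)c1` carries a 3-fluorophenyl group on its core. In this assay compound 1 gives only a limit, > 30 mg/kg, and no number. Compound 2 `O=S(=O)(c1cc(Cl)cc(Cl)c1)c1cnc2cc(F)ccc2c1-c1ccc(F)cc1` instead carries a 4-fluorophenyl group at the same place. In this assay compound 2 likewise reaches only a limit, > 30 mg/kg, so no number places it. Among the measured compounds shown here, both values sit at the same edge of the assay, (the limit of > 30 mg/kg in this assay, at which 2 of the 2 values shown sit), and no step between the two compounds can be sized. Compound 3 `O=S(=O)(c1cc(Cl)cc(Cl)c1)c1cnc2cc(F)ccc2c1-c1cccc(F)c1` differs from compound 2 in one place: 3-fluorophenyl in place of 4-fluorophenyl on an aromatic carbon. That group is the same 3-fluorophenyl that compound 1 carries. For the measured compounds named here, with both measured compounds at a limit there is no sized step to lean on, and the expected step from compound 2 to compound 3, a number no higher from compound 2 to compound 3 (the limit leaves the size open), is none beyond the scatter in either direction. Compound 3 is therefore expected to give about 30 mg/kg in this assay, within a range from 10 mg/kg to 100 mg/kg, with a fair chance that again only a limit is reported.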

Compound 3, minimum effective dose: 30 mg/kg
The estimate for compound 3 equals the measured number at the digits printed, within the range that was stated.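

Among the compounds shown here, compound 3 is the only one of the three compounds that gives a number in this assay, 30 mg/kg. Moving the fluorine, with 3-fluorophenyl in place of 4-fluorophenyl, gives a number no higher from compound 2 to compound 3 (the limit leaves the size open), and the 3,5-dichlorophenyl group in place of 3,5-difluorophenyl on the sulfonyl sulfur gives a number no higher from compound 1 to compound 3 (the limit leaves the size open), so each change has a direction that allows no rise but no size that can be read. The combination of the 3-fluorophenyl and 3,5-dichlorophenyl groups therefore yields a measurable response in the whole animal, yet that number stands at the edge of what the assay reports: the limit of > 30 mg/kg in this assay, at which 2 of the 3 values shown sit.

The compounds shown leave open whether any change at these two places can bring the dose clearly down from that of compound 3, since no value yet lies away from this edge. They also leave open how the response would run with a 2-fluorophenyl group or an unsubstituted phenyl at the place of the fluorophenyl group, or with an amine on the ring carried by the sulfonyl sulfur.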